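The compounds below may be only part of what the source reports. "The series", "measured", "known", "first", "only" and "open" are said of these compounds alone.

Measured compounds:
compound 1 `O=c1nc(NCc2ccc3c(c2)OCCO3)sc2c([N+](=O)[O-])cc(C(F)(F)F)cc12`, > 10000 nM
compound 2 `CCCOCC1COC2(CCN(c3nc(=O)c4cc(C(F)(F)F)cc([N+](=O)[O-])c4s3)CC2)O1`, > 10000 nM

In an ADME assay on HepG2 cells (Homo sapiens) for cytotoxicity, read by MTT assay, with a stated time of 24 h (a higher number here means that more compound is tolerated, a lower number that less compound is tolerated), compound 1 gives > 10000 nM, which is a limit of the assay and not a number. Compound 2 likewise gives only a limit, > 10000 nM. So compound 1 stands at the limit, as does every value shown here (the limit of > 10000 nM in this assay, at which 2 of the 2 values shown sit). Compound 3 `Cc1ccc(CNc2nc(=O)c3cc(C(F)(F)F)cc([N+](=O)[O-])c3s2)n1C` is not yet measured. It differs from compound 1 by 1,5-dimethyl-1H-pyrrol-2-yl in place of 2,3-dihydro-1,4-benzodioxin-6-yl on a saturated chain carbon bound to a nitrogen on an aromatic ring. Within the data shown here, no measured step exists between any two compounds here, so no size can be read from the data. He expects the step that the limit leaves unreadable from compound 1 to compound 3 to lie within the scatter, and estimates compound 3 at 12000 nM, between 5000 nM and 30000 nM.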

Compound 3, half-maximal cytotoxic concentration: > 10000 nM
Compound 3: only a limit was reported (the forecaster's own chance of this, stated with the estimate: 75%); the middle value does not contradict the limit.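

Compound 3 gives > 10000 nM, which is a limit of the assay and not a number. No step from compound 1 to compound 3 can be read, because both values sit at the same limit: the limit of > 10000 nM in this assay, at which 3 of the 3 values shown sit. The compounds shown leave open what actual number any of them would give, and so whether exchanging the group changes tolerance at all.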